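This account rests on a few compounds, and the source may have more. Where it says the series, first, only, none or still open, it means among the compounds named here.

compound 1 `O=C(Nc1ccc(Sc2nc3ccccc3s2)c(Cl)c1)c1cc(Br)cc(Br)c1`: > 100000 nM, a limit
compound 2 `O=C(Nc1ccc(Sc2nc3ccccc3s2)cc1)c1ccccc1O`: 74000 nM
compound 3 `COc1c(Br)cccc1C(=O)Nc1ccc(Sc2nc3ccccc3s2)c(Cl)c1`: > 100000 nM, a limit

All three values come from an ADME assay on HEK293 cells (Homo sapiens) for cytotoxicity, read by reporter gene assay and resazurin assay, with a stated time of 48 h; a lower number here means that less compound is tolerated, a higher number that more compound is tolerated. Compound 3 stands at the limit of > 100000 nM in this assay, at which 2 of the 3 values shown sit, so its entry is a limit and not a number. The next compound is compound 4 `O=C(Nc1ccc(Sc2nc3ccccc3s2)c(Cl)c1)c1ccccc1O`, which carries the following change: a group of 7 heavy atoms (6 carbon, 1 oxygen; one six-membered aromatic ring of carbon only) in place of a group of 9 heavy atoms (7 carbon, 1 oxygen, 1 bromine; one six-membered aromatic ring of carbon only), on a carbonyl carbon. The 2-hydroxyphenyl enters on a carbonyl carbon whose other neighbour is an amide-type nitrogen.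

For the measured compounds named here, the one measured step at this carbonyl carbon is a step that the two limits leave unreadable from compound 1 to compound 3. It offers no size to carry over, so no measured step sizes the change directly. The nearest guide is compound 2, which carries the same 2-hydroxyphenyl and gives 74000 nM. Going by the values given here, that value is the only true number so far, and it rests on a single compound.

A small move towards less compound tolerated is therefore expected, though the assay may again report only a limit. The expected change is an at least 1.2-fold lower number from compound 3 to compound 4 (0.09 log units; that floor lies within the scatter), and this estimate is loose since its starting point is a limit. For compound 4 the estimated value is 80000 nM, with an expected range from 35000 nM to 150000 nM.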

Compound 4, half-maximal cytotoxic concentration: 64000 nM
Compound 4: middle estimate off by 1.3-fold (0.10 log units), on the high side, and the stated range covers the measured number.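

In this assay, 2-hydroxyphenyl on the carbonyl carbon, in place of the group carried by compound 3, gives an at least 1.5-fold lower number from compound 3 to compound 4 (0.19 log units; that floor lies within the scatter), and in place of 3,5-dibromophenyl it gives an at least 1.5-fold lower number from compound 1 to compound 4 (0.19 log units; that floor lies within the scatter). Both sizes are floors and not numbers, and each starts from a limit: the limit of > 100000 nM in this assay, at which 2 of the 4 values shown sit.

Chloro in place of hydrogen on an aromatic carbon, the only step here with a true number at both ends, gives a 1.2-fold lower number from compound 2 to compound 4 (0.06 log units; within the scatter), so this change does not separate the two compounds in this assay when 2-hydroxyphenyl sits on the carbonyl carbon.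

Still open, going by these compounds, is whether any change on the carbonyl carbon moves the number beyond the scatter, and how far the groups of compound 1 and compound 3 actually lie from 2-hydroxyphenyl. Also open, on these data alone, is whether the hydroxyl of 2-hydroxyphenyl matters at all, which a plain phenyl, a 2-aminophenyl or a carboxylic acid on the same ring in that place would test in this assay.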